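The compounds below may be only part of what the source reports. "The series", "measured", "known", "first", "only" and "open" are said of these compounds alone.

Measured compounds:
- compound 1, `CCc1nc2c(-c3ccc(Cl)cc3Cl)ccnc2n1[C@@H](CC)C1CC1`: 0.4 nM
- compound 2, `CCCC(C)n1c(CC)nc2c(-c3ccc(/C(C)=N\OC)cc3Cl)ccnc21`: 2.3 nM
- compound 3, `CCCC(C)n1c(CC)nc2c(-c3ccc(SC)cc3C(F)(F)F)ccnc21`: 1.4 nM

All three were tested in an assay for binding affinity to Corticotropin releasing factor receptor (Rattus norvegicus); on this read-out higher numbers stand for weaker inhibition and lower numbers for stronger inhibition. Compound 1 gives the lowest number of the three; compound 3 stands a step beyond the scatter above it, and compound 2 further still. Compounds 2 and 3 differ from compound 1 in several places at once, so no single change can be read off from those pairs.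

Compound 4, `CCc1nc2c(-c3ccc(Cl)cc3Cl)ccnc2n1C(C)C1CCC1`, has not yet been measured. It keeps the shared core and the ethyl group of compound 1 and changes only the group on the aromatic nitrogen: 1-cyclobutylethyl in place of 1-cyclopropylpropyl on an aromatic nitrogen. The two compounds are built from the same atoms, joined differently; only the small ring and the chain beside it are rearranged.

Within the data shown here, no measured pair isolates this change. The expectation for the step from compound 1 to compound 4 is therefore modest: a 2.0-fold higher number from compound 1 to compound 4 (0.30 log units; within the scatter), a shift that may well stay within the scatter, perhaps a slight weakening. Compound 4 is estimated at 0.8 nM, with a range from 0.25 nM to 2.5 nM.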

Compound 4, inhibition constant: 1 nM
Beside the measured number, compound 4's estimate is 1.3-fold (0.10 log units) below it; the measured number falls inside the stated range.
By their numbers in this assay, from the lowest: compound 1; then compounds 4, 3 and 2 (each within the scatter of the next, the first and the last beyond it).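

In this assay, placing 1-cyclobutylethyl instead of 1-cyclopropylpropyl on the aromatic nitrogen gives a 2.5-fold higher number from compound 1 to compound 4 (0.40 log units; beyond the scatter), the only step shown that isolates a single place. It shows that this position registers a rearrangement of the same atoms, from a three-membered ring to a four-membered one, though only by a modest step that leaves compound 4 at 1 nM, still a low number on this read-out. The ring, the chain and the defined stereocentre all change together in this step, and no evidence is available to account for the shift.

On these data alone, it remains open how each of those three changes contributes on its own. Also open, as far as these compounds go, is how this position would respond to a group containing oxygen, such as a methoxyethyl chain, or to a plain open chain such as 1-ethylpropyl.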